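Oxadiazole aryl swap: compound 3 to compound 4

A few compounds are considered here, and "the series" means these few. Any claim that something is new, unique, unknown or untested is made for them only; others in the source may bear on it.

The shared core appears in compound 1 `Cc1ccc(-n2cc(CCO)nn2)cc1Nc1nccc(-c2cccnc2)n1`, which in a functional assay on HL-60 cells (Homo sapiens) for inhibition, read by MTT assay, with a stated time of 72 h (a higher number here means a weaker inhibitor, a lower number a stronger inhibitor), gives 9100 nM. Compound 2 `Cc1ccc(-c2nnc(-c3ccc(CN4CCN(C)CC4)c(C(F)(F)F)c3)o2)cc1Nc1nccc(-c2cccnc2)n1` carries the oxadiazole bearing a methylpiperazinylmethyl-substituted aryl, and in this assay compound 2 gives 50 nM. Compound 3 `Cc1ccc(-c2nnc(-c3ccc(C)c(C(F)(F)F)c3)o2)cc1Nc1nccc(-c2cccnc2)n1` keeps that aryl with a methyl in place of the chain. For compound 3 this assay reports only a limit, > 30000 nM. The one measured step near this position is an at least 600-fold higher number from compound 2 to compound 3 (2.77 log units; beyond the scatter), ending at the limit of > 30000 nM in this assay, at which 1 of the 3 values shown sits; compound 3 therefore stands at the limit of the three numbers shown.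

Compound 4 `Cc1ccc(-c2nnc(-c3cccnc3)o2)cc1Nc1nccc(-c2cccnc2)n1` differs from compound 3 by pyridin-3-yl in place of 4-methyl-3-(trifluoromethyl)phenyl on an aromatic carbon. For the measured compounds named here, no measured step covers an aryl-for-aryl exchange at this oxadiazole carbon, and the basic chain lost in an at least 600-fold higher number from compound 2 to compound 3 (2.77 log units; beyond the scatter) is absent from compound 4 as well. A step of modest size toward a lower number is expected, an at least 2.0-fold lower number from compound 3 to compound 4 (0.30 log units; that floor lies within the scatter), because compound 3 rests at the limit of > 30000 nM in this assay, at which 1 of the 3 values shown sits, and can only be read downward from there. Compound 4 is expected at 15000 nM, with a range from 4000 nM to 40000 nM.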

Compound 4, half-maximal inhibitory concentration: > 30000 nM
Compound 4: a limit, no number (the forecaster's own chance of this, stated with the estimate: 40%); at least 2.0-fold (0.30 log units) between middle value and limit.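

Compound 3 and compound 4 both rest at a limit of this assay rather than at a number, so no step between them can be read: the limit of > 30000 nM in this assay, at which 2 of the 4 values shown sit.

Still open, as far as these compounds go, is how pyridin-3-yl and 4-methyl-3-(trifluoromethyl)phenyl compare at this position, as neither compound gives a number to set against the other.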